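This account rests on a few compounds, and the source may have more. Where it says the series, first, only, none or still open, it means among the compounds named here.

Working notes on the series. Compound 1 `COc1ccc(-c2cc(/C=C/C(=O)c3ccc(N)cc3)[nH]n2)cc1` and compound 2 `COc1ccc(-c2cc(/C=C/C(=O)c3ccc(N)cc3)[nH]n2)cc1OC` share one core; compound 3 `COc1cc(C(=O)/C=C/c2cc(-c3cc(OC)c(OC)c(OC)c3)n[nH]2)cc(OC)c1OC` carries a different core, and the difference between the two cores is not broken down here. In a functional assay on SR cells (Homo sapiens) for inhibition, read by sulforhodamine B assay, with a stated time of 48 h (a higher number here means a weaker inhibitor of growth, a lower number a stronger inhibitor of growth), compound 1 gives 790 nM, compound 2 gives 580 nM, and compound 3 gives 390 nM. The step of a 1.4-fold higher number from compound 2 to compound 1 (0.13 log units; within the scatter) is made by hydrogen in place of methoxy on an aromatic carbon.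

Compound 4 `COc1ccc(-c2cc(/C=C/C(=O)c3cc(OC)c(OC)c(OC)c3)[nH]n2)cc1OC` is not yet measured. Its difference from compound 3 is hydrogen in place of methoxy on an aromatic carbon. Within the data shown here, this is the same kind of change as the one from compound 2 to compound 1, but not the same: around the place in compound 3 the aromatic carbon is also meta to a methoxy group, which is not so in compound 2.

On this single precedent, compound 4 is expected to sit close to compound 3, with a step of a 1.4-fold higher number from compound 3 to compound 4 (0.15 log units; within the scatter) that is estimated to resemble the earlier one, because the removal of a methoxy gave only a 1.4-fold higher number from compound 2 to compound 1 (0.13 log units; within the scatter) in that pair. The estimate for compound 4 in this assay is therefore 550 nM, expected to fall between 280 nM and 1100 nM.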

Compound 4, concentration for 50% growth inhibition: 200 nM
Compound 4: middle estimate off by 2.8-fold (0.44 log units), on the high side; measured number below the stated range.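

In this assay, hydrogen in place of methoxy on an aromatic carbon gives a 2.0-fold lower number from compound 3 to compound 4 (0.29 log units; within the scatter), and this step cannot be told apart from the earlier one on the other core: the same change on two cores in this assay, a 1.4-fold higher number (0.13 log units; within the scatter) from compound 2 to compound 1 and a 2.0-fold lower number (0.29 log units; within the scatter) from compound 3 to compound 4, 2.7-fold (0.42 log units) apart, within the scatter of two such steps. As far as these two steps go, the change carries from one core to the other without a readable difference, and on neither core does it move the number beyond the scatter. This does not show that the change is without effect in general, or that the core sets its direction, since two steps that each lie within the scatter can fix neither point.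

The compounds shown leave open whether a group other than methoxy at this place, such as a hydroxyl, a fluorine or a longer chain like ethoxy, would behave alike on both cores. Also open, as far as these compounds go, is whether a carboxylic acid there would separate the two cores in this assay.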